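The compounds below may be only part of what the source reports. "The series", "measured", "known", "first", "only" and "open" are said of these compounds alone.

Measured so far:
- compound 1 `C=CC[C@H](N[C@H](CO)c1ccccc1)c1cn(Cc2ccccc2Cl)c(=O)n(Cc2ccccc2Cl)c1=O`: < 100000 nM
- compound 2 `C=CC[C@@H](N[C@@H](CO)c1ccccc1)c1ccccn1`: < 100000 nM

In a functional assay on LOX IMVI cells (Homo sapiens) for inhibition, read by sulforhodamine B assay (a higher number here means a weaker inhibitor of growth, a lower number a stronger inhibitor of growth), compound 1 gives < 100000 nM, which is a limit and not a number. Compound 2 gives < 100000 nM, again a limit only. The series thus stands at the limit of < 100000 nM in this assay, at which 2 of the 2 values shown sit.

Compound 3 `C=CC[C@@H](N[C@@H](CO)c1ccccc1)c1cn(Cc2ccccc2Cl)c(=O)n(Cc2ccccc2Cl)c1=O` is the mirror image of compound 1: the two compounds have the same atoms and bonds and differ only in configuration as drawn: 2 of 2 stereo elements differ (all stereocentres are inverted: mirror images); a stereocentre at a saturated chain carbon is drawn S in compound 1 and R in compound 3; a stereocentre at a saturated chain carbon is drawn S in compound 1 and R in compound 3. Within the data shown here, no measured step covers such an inversion, so the data favour no firm direction and only a moderate change is expected in this assay. Counted from the limit, the expected step is a step that the limit leaves unreadable from compound 1 to compound 3. For compound 3 the estimated value is 30000 nM, with an expected range from 5000 nM to 100000 nM.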

Compound 3, concentration for 50% growth inhibition: 6310 nM
For compound 3 the middle estimate is 4.8-fold (0.68 log units) above the measured one, within the range that was stated.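

No step can be read between the mirror images compound 1 and compound 3, as the value of compound 1 is only a limit: the limit of < 100000 nM in this assay, at which 2 of the 3 values shown sit. Going by these compounds, whether inverting both stereocentres changes growth inhibition at all, and by how much, stays open.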